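This account rests on a few compounds, and the source may have more. Where it says the series, first, only, none or still open, it means among the compounds named here.

Measured compounds in a functional assay on MGC-803 cells (Homo sapiens) for inhibition, read by MTT assay, with a stated time of 72 h; on this read-out lower numbers stand for stronger inhibition and higher numbers for weaker inhibition:
compound 1 `Cc1ccc(-n2cc(CNC(=O)c3cccc4c3cnn4C(C)C)nn2)cc1C` gives > 40000 nM.
compound 2 `CC(C)n1ncc2c(C(=O)NCc3cn(-c4ccc(C(F)(F)F)cc4)nn3)cccc21` gives > 40000 nM.

Compound 2 stands at a limit of this assay, not at a number. Within the data shown here, the step that the two limits leave unreadable from compound 1 to compound 2 is therefore not readable; the only evidence is the limit of > 40000 nM in this assay, at which 2 of the 2 values shown sit. Compound 3 `COc1ccc(-n2cc(CNC(=O)c3cccc4c3cnn4C(C)C)nn2)cc1` differs from compound 2 by methoxy in place of trifluoromethyl on an aromatic carbon. Among the measured compounds shown here, with both neighbours at the limit, no measured step bears on this change, and no movement beyond the scatter is expected: the step of a number no higher from compound 2 to compound 3 (the limit leaves the size open) is my estimate. Compound 3 is expected to give 40000 nM, within 10000 nM to 100000 nM.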

Compound 3, half-maximal inhibitory concentration: > 40000 nM
Compound 3: no number, only a limit; the forecaster's own chance of this, stated with the estimate: 80%; the middle value sits exactly at the limit.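

Compound 3, like compound 1 and compound 2, gives only a limit and not a number, so no step among these three compounds can be read: the limit of > 40000 nM in this assay, at which 3 of the 3 values shown sit.

The compounds shown leave open how strongly any of the three inhibits, and whether these changes of group make any difference.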